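The source may report more compounds than this note shows. Statements on the series, on what has been measured and on what is new or still open speak of the compounds shown alone.

In a functional assay on the whole organism with Mus musculus as the target (a lower number here means that less compound is needed, a higher number that more compound is needed for the effect), compound 1 (`CN1C(=O)CC[C@@H](NC(=O)OCc2ccccc2)C1=O`) gives 24.4 mg/kg and compound 2 (`O=C1CC[C@H](NC(=O)OCc2ccccc2)C(=O)N1`) gives 42.5 mg/kg. These two values lie within the scatter of each other, so compound 2 stands level with compound 1. Compound 3 (`CN1C(=O)CC[C@H](NC(=O)OCc2ccccc2)C1=O`) carries methyl in place of hydrogen on an amide-type nitrogen in a ring of compound 2 (methyl in place of hydrogen on an amide-type nitrogen in a ring). Going by the values given here, no measured pair isolates this change, so the expectation is weakly grounded. The expected step of a 1.3-fold lower number from compound 2 to compound 3 (0.12 log units; within the scatter) stays within the scatter, with no clear direction. For compound 3 the estimated value in this assay is 32 mg/kg, with an expected range of 14 mg/kg to 70 mg/kg.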

Compound 3, dose for half-maximal effect: 12.5 mg/kg
Compound 3: middle estimate off by 2.6-fold (0.41 log units), on the high side, and the stated range ends above it.
By their numbers in this assay, from the lowest: compounds 3, 1 and 2 (each within the scatter of the next, the first and the last beyond it).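

In this assay, methyl in place of hydrogen on the amide-type nitrogen in the ring now has a measured step, a 3.4-fold lower number from compound 2 to compound 3 (0.53 log units; beyond the scatter), which is beyond the scatter but modest. Configuration at the saturated ring carbon gives a 2.0-fold lower number from compound 1 to compound 3 (0.29 log units; within the scatter), which stays within the scatter, so the drawn stereocentre does not separate these two methyl compounds. This reading rests on a single structural difference: the fact that compounds 1 and 3 differ only in the configuration as drawn

As far as these compounds go, whether ethyl or a longer chain on that nitrogen follows the methyl step remains open. Also open is whether the methyl step holds in the configuration of compound 1, which has no hydrogen partner among the compounds shown.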